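Swapping chloro and fluoro on the phenyl group

This account rests on a few compounds, and the source may have more. Where it says the series, first, only, none or still open, it means among the compounds named here.

In an ADME assay on microsomes from liver (Homo sapiens) for metabolic stability, with a stated time of 60 min (on this read-out lower numbers stand for a less stable compound and higher numbers for a more stable compound), compound 3 (`CC(C)(C)C(F)(F)c1cc(-c2onc([C@@H](CCC(=O)O)CC(=O)Nc3ccc(F)cc3Cl)c2C2CC2)no1`) gives 90%. That is level, within the scatter, with compound 1 (`Cc1ccc(NC(=O)CC(CCN)c2nnc(CCCC(C)C)n2C2CC2)c(C)c1`) at 88%, and more stable than compound 2 (`Cc1ccc(NC(=O)C[C@H](CCC(=O)O)c2noc(-c3cc(C(F)(F)C(C)(C)C)on3)c2C2CC2)c(Cl)c1`) at 77%. Compound 4 (`CC(C)(C)C(F)(F)c1cc(-c2onc([C@@H](CCC(=O)O)CC(=O)Nc3ccc(Cl)cc3F)c2C2CC2)no1`) has the same atoms, joined differently: 4-chloro-2-fluorophenyl in place of 2-chloro-4-fluorophenyl on an amide-type nitrogen. Going by the values given here, one measured step bears on this change: a number 13 percentage points higher from compound 2 to compound 3 (beyond the scatter), a modest move in which fluoro replaced methyl on an aromatic carbon. Among the compounds with values here, compound 4 keeps both halogens, and no measured pair shows such a swap, so that step offers only weak guidance. The expected change is small and within the scatter, a number 4 percentage points lower from compound 3 to compound 4 (within the scatter). For compound 4 the estimated value is 86%, with an expected range from 74% to 96%.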

Compound 4, percent of the compound remaining in the Homo sapiens assay: 107%
For compound 4 the middle estimate is 21 percentage points below the measured one; the whole stated range lies below it.
By their numbers in the Homo sapiens assay, from the lowest: compound 2; then compounds 1 and 3 (each within the scatter of the next); then compound 4.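

In the Homo sapiens assay, compound 3 gives 90% and compound 4 gives 107%, and exchanging the places of chloro and fluoro on the phenyl group gives a number 17 percentage points higher from compound 3 to compound 4 (beyond the scatter), so their arrangement matters here, not only which halogens are present. Replacing 2-chloro-4-methylphenyl with 4-chloro-2-fluorophenyl on the same amide-type nitrogen gives a number 30 percentage points higher from compound 2 to compound 4 (beyond the scatter) in the Homo sapiens assay. In a physicochemical assay for lipophilicity (a lower number here means a more polar compound, a higher number a more lipophilic compound), compound 3 gives 4 and compound 4 gives 4.2, and the halogen exchange gives a number 0.20 log units higher from compound 3 to compound 4 (within the scatter).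

Nothing measured here explains the difference in stability. Also open, on these data alone, is how a phenyl group carrying a nitrile or a methoxy group would fare on this nitrogen.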